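Fluoro in place of hydrogen, repeated on a second core

The source may report more compounds than this note shows. Statements on the series, on what has been measured and on what is new or still open speak of the compounds shown alone.

Measured compounds:
compound 1 `c1ccc(Cc2[nH]cnc3ncnc2-3)cc1`: 2%
compound 2 `Fc1ccc(Cc2[nH]cnc3ncnc2-3)cc1`: 8%
compound 3 `Fc1ccc(Cn2cnc3c(Sc4ccccc4)ncnc32)cc1`: 0%

In an assay on isolated protein for inhibition of Ca2+/calmodulin-dependent protein kinase II (CaM kinase II) (Rattus norvegicus), tested at 30 uM (on this read-out lower numbers stand for less inhibition and higher numbers for more inhibition at the one concentration tested (going by the name of the read-out)), compound 1 gives 2% and compound 2 gives 8%. The two differ by fluoro in place of hydrogen on an aromatic carbon, and the step of a number 6 percentage points higher from compound 1 to compound 2 (within the scatter) says nothing beyond the usual scatter. Compound 3 carries a different core; how its core differs from that of compound 1 is not broken down here. In this assay compound 3 gives 0%, within the scatter of both compound 1 and compound 2, so all three sit close to no inhibition at the one concentration tested.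

Compound 4 `Fc1ccc(Cn2cnc3c(Sc4ccc(F)cc4)ncnc32)cc1` differs from compound 3 by fluoro in place of hydrogen on an aromatic carbon, the same change as that from compound 1 to compound 2, at a place described in the same words. For the measured compounds named here, the only measured instance of this change, a number 6 percentage points higher from compound 1 to compound 2 (within the scatter), moved the read-out little. Resting on that step and on the near-zero value of compound 3, 0%, the step of a number 5 percentage points higher from compound 3 to compound 4 (within the scatter) is expected to stay within the scatter as well. Compound 4 is therefore estimated to give 5% in this assay, with a range from 0% to 15%.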

Compound 4, a percentage reported as inhibition, at one concentration (the size of the read-out at that concentration, not a potency): 0%
For compound 4 the middle estimate is 5 percentage points above the measured one; low and high end bracket the measured number.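

In this assay, going from phenylsulfanyl to (4-fluorophenyl)sulfanyl gives no change at the digits printed from compound 3 to compound 4 (within the scatter). Set beside the earlier step, fluoro in place of hydrogen on an aromatic carbon reads the same on both cores: the same change on two cores in this assay, a number 6 percentage points higher (within the scatter) from compound 1 to compound 2 and no change at the digits printed (within the scatter) from compound 3 to compound 4, 6 percentage points apart, within the scatter of two such steps So far the change carries from one core to the other without a step beyond the scatter, but this agreement is between two steps among compounds that all sit close to no inhibition, so it shows neither a direction nor a size for the change and says nothing about how it would act on a compound with clear inhibition.

Still open, going by these compounds, is whether another group on that aromatic carbon, such as an amine or a carboxylic acid, or a longer chain in place of the phenylsulfanyl group, would lift the read-out clear of the scatter. Also open, on these data alone, is whether fluoro in place of hydrogen would still leave this assay unmoved on such a compound.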